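Phenyl in place of 2,4-dichlorophenyl on the shared core

The source may report more compounds than this note shows. Statements on the series, on what has been measured and on what is new or still open speak of the compounds shown alone.

Three aryl variants of the shared core have been measured in a functional assay on B16-F10 cells (Mus musculus) for cytotoxicity; on this read-out higher numbers stand for weaker inhibition and lower numbers for stronger inhibition. Compound 1 `O=c1oc2ccccc2c2nc3c(ccc4cc[nH]c43)c(-c3ccc(Br)cc3)c12` gives 70700 nM. Compound 2 `O=c1oc2ccccc2c2nc3c(ccc4cc[nH]c43)c(-c3ccc([N+](=O)[O-])cc3)c12` gives 70700 nM. Compound 3 `O=c1oc2ccccc2c2nc3c(ccc4cc[nH]c43)c(-c3ccc(Cl)cc3Cl)c12` gives 70700 nM, which places it level with compound 1 and compound 2.

The next compound, compound 4 `O=c1oc2ccccc2c2nc3c(ccc4cc[nH]c43)c(-c3ccccc3)c12`, has phenyl in place of 2,4-dichlorophenyl on an aromatic carbon.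

Three measured steps exchange the group at this same carbon: no change at the digits printed from compound 1 to compound 2 (within the scatter), no change at the digits printed from compound 1 to compound 3 (within the scatter) and no change at the digits printed from compound 2 to compound 3 (within the scatter). None of them goes beyond the scatter. All three measured compounds carry substituents on this phenyl ring, so the unsubstituted ring has not been tested, and the range has to stay wide.

With steps of that size, no shift beyond the scatter is expected in either direction in this assay. The estimated change is no change at the digits printed from compound 3 to compound 4 (within the scatter). For compound 4 the estimate is 70700 nM, with an expected range of 35000 nM to 100000 nM.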

Compound 4, half-maximal inhibitory concentration: 70700 nM
For compound 4 middle estimate and measured number coincide at the digits printed, and the stated range covers the measured number.
By their numbers in this assay, from the lowest: compounds 1, 2, 3 and 4 (each within the scatter of the next).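

With the unsubstituted phenyl now in the set, the bare ring can be set against the substituted ones, and in this assay it does not stand apart from them: removing both chlorines (no change at the digits printed from compound 3 to compound 4 (within the scatter)), the nitro group (no change at the digits printed from compound 2 to compound 4 (within the scatter)) or the bromo group (no change at the digits printed from compound 1 to compound 4 (within the scatter)) leaves every step within the scatter. Across these four compounds, then, bromo, nitro and the two chloro groups cannot be told apart from hydrogen on this phenyl ring by this read-out. Nothing at hand bears on this result.

As far as these compounds go, it remains open whether an amine or a carboxylic acid on the phenyl ring would also leave the read-out flat. The same holds for a cyclohexyl group or a longer alkyl chain in place of the phenyl ring at this carbon.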